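Carbamoyl Added to a Compound Already at the Limit

The source may report more compounds than this note shows. Statements on the series, on what has been measured and on what is new or still open speak of the compounds shown alone.

In an ADME assay on HFF cells (Homo sapiens) for cytotoxicity (on this read-out lower numbers stand for stronger inhibition and higher numbers for weaker inhibition), compound 3 (`Nc1ncnc2c1ccn2C(CO)OC(CO)CO`) reads > 100000 nM, which is a limit and not a number. Compound 4 (`NC(=O)c1cn(C(CO)OC(CO)CO)c2ncnc(N)c12`) differs from it by one change: carbamoyl in place of hydrogen on an aromatic carbon, in words carbamoyl in place of hydrogen on an aromatic carbon. Compound 1 (`NC(=O)c1cn(COC(CO)CO)c2ncnc(N)c12`) also carries carbamoyl, and compound 1 reads > 320000 nM, again a limit. Compound 2 (`NC(=S)c1cn(COC(CO)CO)c2ncnc(N)c12`) reads > 100000 nM, likewise a limit. Among the measured compounds shown here, the only measured step, a step that the two limits leave unreadable from compound 1 to compound 2, has no readable size and so offers no guide to size or direction. No step beyond the scatter is expected in this assay, and the estimated step is a step that the limit leaves unreadable from compound 3 to compound 4. Compound 4 is expected at 250000 nM, with an estimated range of 100000 nM to 400000 nM.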

Compound 4, half-maximal inhibitory concentration: > 100000 nM
Compound 4 was reported as a limit; the forecaster's own chance of this, stated with the estimate: 90%; the middle value does not contradict the limit.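

Compound 4 also reads as a limit, so neither its step from compound 3 nor its step from compound 1 can be read. The compounds shown leave open whether carbamoyl or hydroxymethyl changes the read-out at all.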